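Difluoromethyl in place of allyl on the sulfonamide nitrogen

The source may report more compounds than this note shows. Statements on the series, on what has been measured and on what is new or still open speak of the compounds shown alone.

Among the measured compounds shown here, the series so far consists of compound 1 `C=CCN(c1ccccc1C)S(=O)(=O)c1cc(Cl)ccc1Cl` and compound 2 `C=CCN(c1ccc(Cl)cc1C)S(=O)(=O)c1cc(Cl)ccc1Cl`, both tested in an ADME assay on A549 cells (Homo sapiens) for cytotoxicity, read by MTT assay; on this read-out higher numbers stand for lower toxicity in this test and lower numbers for higher toxicity in this test. Compound 1 gives > 5000 nM, which is a limit of the assay and not a number. Compound 2 gives > 5000 nM, which is also a limit and not a number. Compound 2 therefore has no numerical position, and the evidence so far is the limit of > 5000 nM in this assay, at which 2 of the 2 values shown sit.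

The next structure is compound 3 `Cc1cc(Cl)ccc1N(C(F)F)S(=O)(=O)c1cc(Cl)ccc1Cl`, with this change: difluoromethyl in place of allyl on a sulfonamide nitrogen. For the measured compounds named here, the only measured step is a step that the two limits leave unreadable from compound 1 to compound 2, with chloro in place of hydrogen on an aromatic carbon. It has no readable size and does not involve the sulfonamide nitrogen, so it gives no guide to the size or direction of the new step. No change beyond the scatter is expected in this assay, and a further limit is the likeliest outcome. The expected step is a step that the limit leaves unreadable from compound 2 to compound 3. For compound 3 the estimated value is 6000 nM, with an expected range from 2500 nM to 15000 nM.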

Compound 3, half-maximal cytotoxic concentration: > 5000 nM
Compound 3 was reported as a limit (the forecaster's own chance of this, stated with the estimate: 75%); the middle value does not contradict the limit.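

The step to compound 3 cannot be read: compound 2 and compound 3 both stand at a limit of this assay and not at a number, so difluoromethyl in place of allyl has no readable size. The compounds shown leave open whether any change to the shared core would give a numerical value, since all of them stand at one limit: the limit of > 5000 nM in this assay, at which 3 of the 3 values shown sit.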